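The source may hold more compounds than are shown below. What is called first, only, known or untested is meant among the compounds shown, and "the series" means these compounds.

Measured compounds:
Compound 1, `O=C(/C=C\Nc1ccc(F)cc1)c1nc(-c2ccc(C(F)(F)F)cc2)n2ccccc12`. In a functional assay on BT-474 cells (Homo sapiens) for cytotoxicity, read by MTT assay, with a stated time of 48 h (a higher number here means a weaker inhibitor, a lower number a stronger inhibitor), compound 1 gives only a limit of the assay, > 30000 nM.
Compound 2, `COc1ccc(N/C=C\C(=O)c2nc(-c3ccc(F)cc3)n3ccccc23)cc1OC`. In this assay compound 2 gives only a limit of the assay, > 30000 nM.
Compound 3, `O=C(/C=C\Nc1cnc2ccccc2c1)c1nc(-c2ccc(C(F)(F)F)cc2)n2ccccc12`. In this assay compound 3 gives only a limit of the assay, > 30000 nM.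

Compound 1 therefore stands at the edge of what this assay can report: no number, only a limit, and the same holds for every compound measured here, since (the limit of > 30000 nM in this assay, at which 3 of the 3 values shown sit). For the measured compounds named here, the one change that links two measured compounds, a step that the two limits leave unreadable from compound 1 to compound 3, cannot be read at all, as both ends sit at that limit. Compound 2 and compound 1 differ in more than one place, so their two values show only that both are limits.

The new compound is compound 4, `COc1ccc(-c2nc(C(=O)/C=C\Nc3ccc(F)cc3)c3ccccn23)cc1`. Relative to compound 1 the change is methoxy in place of trifluoromethyl on an aromatic carbon. Going by the values given here, no measured step touches this part of the shared core, so the expectation rests on the observation that all three measured compounds sit at the limit. Compound 4 is therefore expected to give about 40000 nM, somewhere between 15000 nM and 120000 nM, most likely again only a limit. The expected step that the limit leaves unreadable from compound 1 to compound 4 is none beyond the scatter.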

Compound 4, half-maximal inhibitory concentration: > 30000 nM
Compound 4: only a limit was reported; the forecaster's own chance of this, stated with the estimate: 85%; the middle value does not contradict the limit.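

In this assay compound 4 gives > 30000 nM as a limit only, and compound 1 is also only a limit, so no step can be read for replacing trifluoromethyl with methoxy. The compounds shown leave open how strongly any of them acts on these cells, and whether any change among them makes a difference.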